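Removing a Chloro Group: Two Scaffolds, One Read-out

The source may hold more compounds than are shown below. What is called first, only, known or untested is meant among the compounds shown, and "the series" means these compounds.

Of the compounds shown here, three have been tested in an assay on isolated protein for inhibition of Alpha glucosidase (Homo sapiens), with stated times of 5 min and 15 min, tested at 50 uM; on this read-out higher numbers stand for more inhibition at the one concentration tested (going by the name of the read-out) and lower numbers for less inhibition. Compound 1, `O=C1/C(=C/c2ccccc2)CCC/C1=C\c1ccc(Cl)cc1`, gives 27.6%. Compound 2, `O=C1/C(=C/c2ccccc2)CCC/C1=C\c1ccc(Cl)c(Cl)c1`, gives 48.4%. The two share a core and differ in one place: hydrogen in place of chloro on an aromatic carbon. That step is a number 20.8 percentage points lower from compound 2 to compound 1 (beyond the scatter).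

Compound 3, `O=C(/C=C(O)/C=C/c1cccc(O)c1)c1cc(Cl)ccc1O`, is built on a different core; how the two cores differ is not broken down here. In this assay compound 3 gives 62.4%, the highest of the three numbers, beyond the scatter above both compound 2 and compound 1.

Compound 4, `O=C(/C=C(O)/C=C/c1cccc(O)c1)c1ccccc1O`, has not yet been measured. It stands to compound 3 as compound 1 stands to compound 2: hydrogen in place of chloro on an aromatic carbon. This is the same kind of change as from compound 2 to compound 1, though the surroundings differ. In compound 2 the leaving chloro sits ortho to a chloro group and meta to a large group; in compound 3 it sits meta to a large group and para to a hydroxy group. Since the change was seen only once and on another core, a drop is expected but its size is uncertain. For compound 4 the expected step is a number 16.4 percentage points lower from compound 3 to compound 4 (beyond the scatter), resting on the measured step of a number 20.8 percentage points lower from compound 2 to compound 1 (beyond the scatter). Compound 4 is therefore estimated to give 46%, within a range from 30% to 62%.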

Compound 4, a percentage reported as inhibition, at one concentration (the size of the read-out at that concentration, not a potency): 40.4%
Estimate against measurement, compound 4: 5.6 percentage points above; measured number inside the range.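

Replacing chloro with hydrogen on the core of compound 3 gives a number 22 percentage points lower from compound 3 to compound 4 (beyond the scatter) in this assay. Set beside the same replacement on the other core, the two steps agree, so in this series the loss seen on one core was a fair guide to the loss on the other: the same change on two cores in this assay, a number 20.8 percentage points lower (beyond the scatter) from compound 2 to compound 1 and a number 22 percentage points lower (beyond the scatter) from compound 3 to compound 4, 1.2 percentage points apart, within the scatter of two such steps This rests on only two pairs of compounds, with different surroundings around the chloro group in each pair and a single concentration that gives the size of the read-out rather than a potency, so it does not make the step a rule for other cores and does not explain why removing chloro lowers the number.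

The compounds shown leave open whether a fluoro, bromo or methyl group in the same place would give a number closer to that of chloro or to that of hydrogen. Also open, from the compounds shown here alone, is whether the two steps would still agree on a third core, or for a chloro group sitting elsewhere on the ring of either core.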